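The compounds below may be only part of what the source reports. "The series", "measured", "known", "first", "only" and "open" are said of these compounds alone.

Compound 1 `CSc1nc(NCCCCNc2ccnc3cc(Cl)ccc23)c(C#N)c(-c2ccccc2)n1` was tested in an ADME assay on HeLa cells (Homo sapiens) for inhibition, read by cell counting (a lower number here means a stronger inhibitor, a higher number a weaker inhibitor), and gave 8500 nM. Of the two plain numbers in this small set, compound 1 stands at the highest, and its nearest neighbour is compound 2 `CSc1nc(OCCCNc2ccnc3cc(Cl)ccc23)c(C#N)c(-c2ccccc2)n1`, which gives 3400 nM in this assay, a gap that lies beyond the usual scatter of such measurements. Compound 3 `CSc1nc(-c2ccccc2)c(C#N)c(N2CCN(c3ccnc4cc(Cl)ccc34)CC2)n1` returns a limit of the assay rather than a number, > 250000 nM. That reading is the limit of > 250000 nM in this assay, at which 1 of the 3 values shown sits.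

Compound 4 `CSc1nc(NCCCCNc2ccnc3cc(Cl)ccc23)c(C#N)c(-c2ccc([N+](=O)[O-])cc2)n1` has not yet been measured. It differs from compound 1 in one place only, on the phenyl ring of the shared core: nitro in place of hydrogen on an aromatic carbon, para to a large group, so that phenyl becomes 4-nitrophenyl. Among the measured compounds shown here, no measured pair in this set shows what such a change does, so any expectation rests on compound 1 alone. The nitro group is expected to move the number little, if at all. A step of a 1.2-fold lower number from compound 1 to compound 4 (0.08 log units; within the scatter) is estimated, which would sit within the usual scatter. Compound 4 is therefore expected to give about 7000 nM in this assay, with a range from 2500 nM to 25000 nM.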

Compound 4, half-maximal inhibitory concentration: 890 nM
Beside the measured number, compound 4's estimate is 7.9-fold (0.90 log units) above it; the measured number lies below the stated range.
By their numbers in this assay, from the lowest: compound 4; then compound 2; then compound 1. At a limit, above all of these: compound 3.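

The phenyl ring of the shared core turns out not to be a silent place in this assay: with nitro in place of hydrogen on an aromatic carbon, para to a large group, the data show a 9.6-fold lower number from compound 1 to compound 4 (0.98 log units; beyond the scatter), a change of one group that lies well beyond the scatter. Among the compounds shown here, compounds 1, 2 and 3 all carry the same plain phenyl, so they could say nothing about this ring, and this single pair is the first sign that a substituent there can shift the number. Nothing measured in this set accounts for the size of the step, and the one limit on record bears on a different compound.

For the compounds shown here, with only this one pair, it remains open whether the shift belongs to nitro itself or would also appear with another group at the same place, such as an amine, a methoxy group, a chlorine atom or a carboxylic acid. Also open, going by these compounds, is whether 4-nitrophenyl would act in the same way on the oxygen-linked chain of compound 2 or on a longer chain.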